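A few compounds are considered here, and "the series" means these few. Any claim that something is new, unique, unknown or untested is made for them only; others in the source may bear on it.

Measured compounds:
compound 1, `CC(O)(CSc1cc(C(F)(F)F)cc(C(F)(F)F)c1)C(=O)Nc1ccc(C(F)(F)F)cc1`: 9610 nM
compound 2, `CC(O)(COc1cc(C(F)(F)F)cc(C(F)(F)F)c1)C(=O)Nc1ccc(C#N)cc1C(F)(F)F`: 3560 nM
compound 3, `CC(O)(CS(=O)(=O)c1cccc(C(F)(F)F)c1)C(=O)Nc1cc(C(F)(F)F)cc(C(F)(F)F)c1`: 9500 nM

The three compounds share a common core and were tested in a functional assay on LNCaP cells (Homo sapiens) for antiproliferative activity, read by fluorescence and propidium iodide staining, with a stated time of 96 h; on this read-out lower numbers stand for stronger inhibition and higher numbers for weaker inhibition. Compound 3 sits at the second highest of the three numbers. Its nearest neighbour is compound 1, whose number lies within the usual scatter of compound 3, so the two cannot be told apart. Compound 2 gives a lower number than compound 3, and that gap lies beyond the scatter.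

Among the compounds with values here, compound 4, `CC(O)(CS(=O)(=O)c1ccccc1C(F)(F)F)C(=O)Nc1cc(C(F)(F)F)cc(C(F)(F)F)c1`, is the only untested member. It differs from compound 3 in one respect: 2-(trifluoromethyl)phenyl in place of 3-(trifluoromethyl)phenyl on a sulfonyl sulfur. The two compounds are built from the same atoms, joined differently, so only the placement of the trifluoromethyl group on the aryl ring attached to the sulfonyl sulfur changes.

Within the data shown here, no measured pair shows this kind of change, so there is nothing to calibrate it against. For compound 4 the step from compound 3 is expected to be small, a 1.1-fold higher number from compound 3 to compound 4 (0.02 log units; within the scatter), and not beyond the scatter in either direction. Compound 4 is therefore expected to give about 10000 nM in this assay, with a likely range from 4000 nM to 30000 nM.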

Compound 4, half-maximal inhibitory concentration: 8510 nM
Beside the measured number, compound 4's estimate is 1.2-fold (0.07 log units) above it; measured number inside the range.
By their numbers in this assay, from the lowest: compound 2; then compounds 4, 3 and 1 (each within the scatter of the next).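

In this assay, replacing 3-(trifluoromethyl)phenyl with 2-(trifluoromethyl)phenyl on a sulfonyl sulfur gives a 1.1-fold lower number from compound 3 to compound 4 (0.05 log units; within the scatter), so the two compounds cannot be told apart. Within the data shown here, this is the first pair in the set that differs in one place only, and it gives the first direct look at this part of the structure: for these two aryl groups, the placement of the trifluoromethyl group makes no readable difference to the antiproliferative number. Among these compounds, nothing available here explains this result, so the pair records only that the number stays within the scatter and gives no reason for it.

This single pair cannot show whether the aryl ring on the sulfonyl sulfur tolerates other changes, such as an amine or a carboxylic acid in place of the trifluoromethyl group. Compound 2 differs from compound 3 and compound 4 in more than one place, so its number cannot be credited to any single part of its structure, and the contribution of the sulfonyl link itself remains unresolved.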